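This account rests on a few compounds, and the source may have more. Where it says the series, first, only, none or still open, it means among the compounds named here.

Measured in a functional assay (Platelet, plasma) for inhibition, with Homo sapiens as the target; a lower number here means a stronger inhibitor, a higher number a weaker inhibitor:
- Compound 1 `N#Cc1cc2c(nc1N1CCC(F)(C(=O)NS(=O)(=O)Cc3ccc(Cl)cc3)CC1)COC2=O`: 37200 nM
- Compound 2 `CC1(C(=O)NS(=O)(=O)Cc2ccc(Cl)cc2)CCN(c2nc3c(cc2C#N)C(=O)OC3)CC1`: 3010 nM
- Compound 3 `N#Cc1cc2c(nc1N1CCC(C(=O)NS(=O)(=O)Cc3ccc(Cl)cc3)CC1)COC2=O`: 4420 nM

Compound 1 has the highest number of the three, which makes it the weakest inhibitor of this small set. Replacing its fluoro on a saturated ring carbon gives a clear gain in both cases. Methyl in that place gives a 12-fold lower number from compound 1 to compound 2 (1.09 log units; beyond the scatter), and hydrogen gives an 8.4-fold lower number from compound 1 to compound 3 (0.93 log units; beyond the scatter). Exchanging those two groups gives a 1.5-fold higher number from compound 2 to compound 3 (0.17 log units; within the scatter), which is within the scatter.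

The next compound, compound 4 `N#Cc1cc2c(nc1N1CCC(F)(C(=O)NS(=O)(=O)Cc3ccccc3)CC1)COC2=O`, keeps the fluoro and changes the far end of the molecule instead, turning 4-chlorobenzyl into benzyl: hydrogen in place of chloro on an aromatic carbon. Within the data shown here, none of the measured steps touches this chloro, since all three concern the saturated ring carbon. Among the measured compounds shown here, their sizes therefore say little about this change, and no measured pair shows what removing the chloro does. The expectation starts from compound 1 at 37200 nM, and with no evidence for a shift, no step beyond the scatter is expected. The expected change is a 1.2-fold higher number from compound 1 to compound 4 (0.08 log units; within the scatter). The uncertainty is wide, and a result reported only as a limit is possible. For compound 4 the estimate is 45000 nM, with an expected range from 14000 nM to 140000 nM.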

Compound 4, half-maximal inhibitory concentration: 1210 nM
For compound 4 the middle estimate is 37-fold (1.57 log units) above the measured one; the whole stated range lies above it.
By their numbers in this assay, from the lowest: compound 4; then compounds 2 and 3 (each within the scatter of the next); then compound 1.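

In this assay, removing the chloro from the 4-chlorobenzyl group while keeping the fluoro gives a large gain in inhibition (a 31-fold lower number from compound 1 to compound 4 (1.49 log units; beyond the scatter)), so the far end of the molecule can also shift this number strongly, not only the saturated ring carbon. Measured from the same starting compound, this is the largest of the three printed steps, ahead of exchanging the fluoro for methyl (a 12-fold lower number from compound 1 to compound 2 (1.09 log units; beyond the scatter)) or for hydrogen (an 8.4-fold lower number from compound 1 to compound 3 (0.93 log units; beyond the scatter)), and it shows that a fluoro on the ring carbon does not prevent a large gain. No measurement shown here explains why losing this single chlorine atom has an effect of this size.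

As far as these compounds go, the benzyl group appears here only with fluoro on the ring carbon, so it remains open whether the same gain would be seen with methyl or hydrogen there. From the compounds shown here alone, it is also open how a methoxy group or a bromine atom at the same place on the aromatic ring would compare with hydrogen and chloro.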